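This account rests on a few compounds, and the source may have more. Where it says the series, first, only, none or still open, it means among the compounds named here.

Compound 1 `Cc1nc(-c2ccccc2)sc1C(=O)CSc1nc(-c2ccccc2)c(C#N)c(=O)[nH]1` gives 56600 nM in a functional assay on U-87MG ATCC cells for antiproliferative activity against U-87 MG (Homo sapiens), read by MTT assay, with a stated time of 48 h; a lower number here means a stronger inhibitor, a higher number a weaker inhibitor.
Compound 2 `COc1cccc(-c2nc(SCC(=O)c3sc(-c4ccccc4)nc3C)[nH]c(=O)c2C#N)c1` gives 59700 nM in this assay.
Compound 3 `Cc1nc(-c2ccccc2)sc1C(=O)CSc1nc(-c2cccc(Cl)c2)c(C#N)c(=O)[nH]1` gives 28200 nM in this assay.

Compound 3 has the lowest number of the three in this assay. Its distance from compound 1 is a 2.0-fold lower number from compound 1 to compound 3 (0.30 log units; within the scatter), which lies within the scatter, while its distance from compound 2 is a 2.1-fold lower number from compound 2 to compound 3 (0.33 log units; beyond the scatter), a modest step beyond the scatter. Compound 3 is therefore not clearly separated from compound 1, only from compound 2.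

Compound 4 `Cc1nc(-c2ccccc2)sc1C(=O)CSc1nc(-c2ccc(Cl)c(Cl)c2)c(C#N)c(=O)[nH]1` differs from compound 3 by chloro in place of hydrogen on an aromatic carbon, that is, the shared core now carries 3,4-dichlorophenyl instead of 3-chlorophenyl. The measured steps that bear on this are those in which a chloro was introduced on the same ring: a 2.0-fold lower number from compound 1 to compound 3 (0.30 log units; within the scatter) and a 2.1-fold lower number from compound 2 to compound 3 (0.33 log units; beyond the scatter). Both were small, and only one reached beyond the scatter. A second chloro is therefore expected to shift this assay by at most a small amount, toward a lower number, or not beyond the scatter at all. The expected step is a 1.4-fold lower number from compound 3 to compound 4 (0.15 log units; within the scatter). Compound 4 is thus estimated at 20000 nM, with a range from 9000 nM to 45000 nM.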

Compound 4, half-maximal inhibitory concentration: 65000 nM
The estimate for compound 4 lay 3.3-fold (0.51 log units) below the measured number; measured number above the stated range.
By their numbers in this assay, from the lowest: compounds 3, 1, 2 and 4 (each within the scatter of the next, the first and the last beyond it).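

In this assay, a second chloro on the ring, ortho to the chloro group of compound 3, does not add to the effect of the first: the result is a 2.3-fold higher number from compound 3 to compound 4 (0.36 log units; beyond the scatter) and so a modest move back. The 3,4-dichlorophenyl group gives no separation from phenyl, with a 1.1-fold higher number from compound 1 to compound 4 (0.06 log units; within the scatter), or from 3-methoxyphenyl, with a 1.1-fold higher number from compound 2 to compound 4 (0.04 log units; within the scatter), so among these four compounds 3-chlorophenyl alone stands apart, and only from compound 2 and compound 4, not from compound 1. No measurement shown here accounts for this result.

From the compounds shown here alone, it remains open how a lone chloro at the newly substituted carbon would compare with the 3-chlorophenyl of compound 3. Going by these compounds, it is also open whether an amine or a carboxylic acid on this ring would shift the number any further than these groups have.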